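Anilide in Place of Acid on Two Aryl Cores

The source may report more compounds than this note shows. Statements on the series, on what has been measured and on what is new or still open speak of the compounds shown alone.

In a functional assay on HeLa cells (Homo sapiens) for cytotoxicity, read by MTT assay, with a stated time of 24 h (on this read-out higher numbers stand for weaker inhibition and lower numbers for stronger inhibition), compound 1 `C=CC1=C(C(=O)O)C(c2ccc(F)cc2)OC1` gives 67400 nM. Compound 2 `C=CC1=C(C(=O)Nc2ccccc2)C(c2ccc(F)cc2)OC1` differs from compound 1 by anilino in place of hydroxy on a carbonyl carbon. For compound 2 this assay reports only a limit, > 100000 nM, which is the limit of > 100000 nM in this assay, at which 1 of the 3 values shown sits. The step of an at least 1.4-fold higher number from compound 1 to compound 2 (0.17 log units; that floor lies within the scatter) therefore rests on a floor rather than on a number.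

Compound 3 `C=CC1=C(C(=O)O)C(c2ccc(OC)c(OC)c2)OC1` carries a different core; the difference between the two cores is not broken down here. In this assay compound 3 gives 18000 nM, the lowest of the two numbers available, and its gap to compound 1 lies beyond the scatter.

Compound 4 `C=CC1=C(C(=O)Nc2ccccc2)C(c2ccc(OC)c(OC)c2)OC1` has not yet been measured in this assay. For the measured compounds named here, it differs from compound 3 by anilino in place of hydroxy on a carbonyl carbon, the same change as the one made from compound 1 to compound 2, at the same place on the carbonyl carbon. Going by the values given here, the only measured instance of this change ended at a limit, so its true size is known only as a floor.

On that footing the author expects the step of a 2.8-fold higher number from compound 3 to compound 4 (0.44 log units; beyond the scatter), a higher number, because the step of an at least 1.4-fold higher number from compound 1 to compound 2 (0.17 log units; that floor lies within the scatter) also moved the number upward. Since compound 3 starts lower than compound 1, a numerical result is thought somewhat more likely for compound 4 than it was for compound 2. For compound 4 in this assay the estimate is 50000 nM, with a range from 15000 nM to 150000 nM.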

Compound 4, half-maximal inhibitory concentration: 5030 nM
For compound 4 the middle estimate is 9.9-fold (1.00 log units) above the measured one; measured number below the stated range.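

On the core of compound 3, anilino in place of hydroxy on the carbonyl carbon gave a 3.6-fold lower number from compound 3 to compound 4 (0.55 log units; beyond the scatter), so in this assay the change did not keep the direction seen on the core of compound 1, and the two steps differ by more than the scatter: the same change on two cores in this assay, an at least 1.4-fold higher number (0.17 log units; that floor lies within the scatter) from compound 1 to compound 2 and a 3.6-fold lower number (0.55 log units; beyond the scatter) from compound 3 to compound 4, at least 5.3-fold (0.72 log units) apart, beyond the scatter of two such steps Compound 2 carries a limit and not a number, so the step on the core of compound 1 is known only as a floor: the limit of > 100000 nM in this assay, at which 1 of the 4 values shown sits. The two pairs show that the outcome of this change in this series depends on the core it is made on, but they do not show which feature of the two cores decides it, and they give no rule for any further core.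

The compounds shown leave open whether the lower number on the core of compound 3 belongs to the anilino group itself or would also appear with a simpler amide, such as a methylamide, or with a methyl ester in place of the carboxylic acid. They also leave open how an anilino group bearing a methoxy group or a fluorine on its ring would fare on either core.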